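The source may report more compounds than this note shows. Statements on the series, on what has been measured and on what is new or still open speak of the compounds shown alone.

The account follows one change on a shared core. Compound 1 `C=CCN(C)C(=O)c1ccc(C(CC)(CC)c2ccc(OCCC(O)(CC)CC)c(C)c2)n1CC` carries an allyl(methyl)amino group on a carbonyl carbon. In a functional assay on MCF7 cells (Homo sapiens) for antiproliferative activity, read by MTT assay, with a stated time of 48 h (on this read-out lower numbers stand for stronger inhibition and higher numbers for weaker inhibition), compound 1 reaches only a limit of the assay, > 50000 nM. Compound 2 `CCn1c(C(=O)NC(C)C(=O)O)ccc1C(CC)(CC)c1ccc(OCCC(O)(CC)CC)c(C)c1` gives 19700 nM in this assay, and compound 3 `CCC(C)C(CO)NC(=O)c1ccc(C(CC)(CC)c2ccc(OCCC(O)(CC)CC)c(C)c2)n1CC` gives 29100 nM. Two measured steps start from the same parent: an at least 2.5-fold lower number from compound 1 to compound 2 (0.40 log units; beyond the scatter), and an at least 1.7-fold lower number from compound 1 to compound 3 (0.23 log units; that floor lies within the scatter). Between the two measured amides, a 1.5-fold higher number from compound 2 to compound 3 (0.17 log units; within the scatter). Compound 4 `CCn1c(C(=O)NC(C)CO)ccc1C(CC)(CC)c1ccc(OCCC(O)(CC)CC)c(C)c1` has not been measured; its difference from the parent reads ((1-(hydroxymethyl)ethyl)amino in place of allyl(methyl)amino on a carbonyl carbon). Like compound 3, compound 4 carries a hydroxymethyl on the amide-type nitrogen, so the closest guide is the step of an at least 1.7-fold lower number from compound 1 to compound 3 (0.23 log units; that floor lies within the scatter), whose size is uncertain at its floor because the parent sits at the limit of > 50000 nM in this assay, at which 1 of the 3 values shown sits. A modest lowering is therefore expected, with a real chance that the assay again reports only a limit. The expected step is an at least 1.6-fold lower number from compound 1 to compound 4 (0.22 log units; that floor lies within the scatter). Compound 4 is expected to give 30000 nM, within a range from 12000 nM to 80000 nM.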

Compound 4, half-maximal inhibitory concentration: 12600 nM
For compound 4 the middle estimate is 2.4-fold (0.38 log units) above the measured one, and the stated range covers the measured number.
By their numbers in this assay, from the lowest: compounds 4, 2 and 3 (each within the scatter of the next, the first and the last beyond it). At a limit, above all of these: compound 1.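

With (1-(hydroxymethyl)ethyl)amino on the carbonyl carbon, an amide carrying a hydroxymethyl now stands clear of the parent beyond the scatter, which the floor for compound 3 did not, though this size too is only a floor: the limit of > 50000 nM in this assay, at which 1 of the 4 values shown sits. The two hydroxymethyl amides also separate from each other in this assay, with methyl in place of sec-butyl giving a 2.3-fold lower number from compound 3 to compound 4 (0.36 log units; beyond the scatter), and the full step from the parent reads an at least 3.9-fold lower number from compound 1 to compound 4 (0.59 log units; beyond the scatter). Hydroxymethyl in place of carboxy gives a 1.6-fold lower number from compound 2 to compound 4 (0.19 log units; within the scatter), so the two groups are not told apart on this read-out.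

From the compounds shown here alone, what a primary amine in place of the hydroxymethyl, or an ethyl in place of the methyl, would give in this assay remains open. Also open, going by these compounds, is how much of the step from compound 1 belongs to the amide hydrogen and how much to the hydroxymethyl, as the two enter together.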